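The source may hold more compounds than are shown below. What is called first, only, known or untested is meant among the compounds shown, and "the series" means these compounds.

Measured compounds in an ADME assay on HepG2 cells (Homo sapiens) for cytotoxicity, read by MTT assay, with a stated time of 24 h; a higher number here means that more compound is tolerated, a lower number that less compound is tolerated:
Compound 1 `CC(C)=CCC1=C(OCc2cn(C3CCN(C(=O)OC(C)(C)C)CC3)nn2)C(=O)c2ccccc2C1=O`: 136000 nM
Compound 2 `CC(C)=CCC1=C(OCc2cn(C3CCNCC3)nn2)C(=O)c2ccccc2C1=O`: 570000 nM
Compound 3 `CC(C)=CCC1=C(OCc2cn(Cc3ccccc3)nn2)C(=O)c2ccccc2C1=O`: 414000 nM

Among these three, compound 2 carries the highest number, though compound 3 sits within the usual scatter of it: a 1.4-fold lower number from compound 2 to compound 3 (0.14 log units; within the scatter). Compound 1 lies clearly lower, since a 4.2-fold higher number from compound 1 to compound 2 (0.62 log units; beyond the scatter).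

Compound 4 `CC(C)=CCC1=C(OCc2cn(Cc3ccccn3)nn2)C(=O)c2ccccc2C1=O` is not yet measured. It differs from compound 2 in one place: (pyridin-2-yl)methyl in place of piperidin-4-yl on an aromatic nitrogen.

The step that bears most on this change is the one in which benzyl replaced piperidin-4-yl on the same aromatic nitrogen, a 1.4-fold lower number from compound 2 to compound 3 (0.14 log units; within the scatter), which stayed within the scatter. The group entering in compound 4 resembles benzyl in size and shape, differing by a ring nitrogen in the aromatic ring. On this single comparison, no step beyond the scatter is expected in this assay from compound 2 to compound 4, with at most a slight drift toward a lower number, as seen for compound 3.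

Compound 4 is therefore estimated at 450000 nM in this assay, with a range from 200000 nM to 1000000 nM, which corresponds to an expected step of a 1.3-fold lower number from compound 2 to compound 4 (0.10 log units; within the scatter).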

Compound 4, half-maximal cytotoxic concentration: 658000 nM
The estimate for compound 4 lay 1.5-fold (0.17 log units) below the measured number, and the stated range covers the measured number.
By their numbers in this assay, from the lowest: compound 1; then compounds 3, 2 and 4 (each within the scatter of the next).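

In this assay, the step to (pyridin-2-yl)methyl on this aromatic nitrogen is a 1.2-fold higher number from compound 2 to compound 4 (0.06 log units; within the scatter), so an aromatic ring with no hydrogen-bond donor can stand in for the non-aromatic piperidin-4-yl ring, which has one, without a readable difference. Pyridin-2-yl in place of phenyl on the chain carbon, which adds a ring nitrogen to the benzyl group, is a 1.6-fold higher number from compound 3 to compound 4 (0.20 log units; within the scatter), so that change cannot be told apart from the scatter either. Nothing available explains why these groups give such close numbers.

The compounds shown leave open whether (pyridin-3-yl)methyl or a longer chain such as 2-(pyridin-2-yl)ethyl would stay as close. They also leave open whether a carboxylic acid on the benzyl ring would keep the number in this range.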